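Phenyl in Place of Methyl on a Shared Core

The source may report more compounds than this note shows. Statements on the series, on what has been measured and on what is new or still open speak of the compounds shown alone.

Compound 1 `CC/N=C(\NC#N)NCCSCn1nc(C)ccc1=O` was examined in a functional assay on the whole organism (stomach) for inhibition, with Rattus norvegicus as the target, with a stated time of 4 h; on this read-out lower numbers stand for an effect already at smaller amounts and higher numbers for an effect only at larger amounts of compound. In this assay compound 1 reaches only the limit > 100 mg/kg, so no number is known for it, only that limit. Two further compounds on the same core carry an aromatic group where compound 1 carries methyl. Compound 2 `C/N=C(\NC#N)NCCSCn1nc(-c2ccc(Cl)cc2)ccc1=O` in this assay gives < 39.1 mg/kg, which is again a limit and not a number. Compound 3 `C/N=C(\NC#N)NCCSCn1nc(-c2ccc(C)cc2)ccc1=O` in this assay gives < 53.8 mg/kg, also a limit. Among the measured compounds shown here, the only step between measured compounds, a step that the two limits leave unreadable from compound 2 to compound 3, cannot be read from the two limits, and it concerns a different change. Compound 4 `CC/N=C(\NC#N)NCCSCn1nc(-c2ccccc2)ccc1=O` differs from compound 1 in one place: phenyl in place of methyl on an aromatic carbon. For the measured compounds named here, no measured step covers exactly this change. What the numbers show is that compound 1 sits at the limit (the limit of > 100 mg/kg in this assay, at which 1 of the 3 values shown sits), whereas the two compounds bearing an aromatic group sit at the limits the limit of < 39.1 mg/kg in this assay, at which 1 of the 3 values shown sits, and (the limit of < 53.8 mg/kg in this assay, at which 1 of the 3 values shown sits). On that basis a step towards an effect at smaller amounts is expected for compound 4, an at least 3.3-fold lower number from compound 1 to compound 4 (0.52 log units; beyond the scatter), beyond the usual scatter. Compound 4 is therefore estimated at 30 mg/kg in this assay, with a range from 10 mg/kg to 100 mg/kg.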

Compound 4, dose for half-maximal effect: < 100 mg/kg
Compound 4 ended at the assay's limit; the forecaster's own chance of this, stated with the estimate: 40%; the middle value lies beyond the limit too.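

Phenyl in place of methyl on an aromatic carbon now has a step of its own in this assay (a reading of a number no higher from compound 1 to compound 4 (the limit leaves the size open)), with the rest of the shared core left as it stands in compound 1. Compound 4 stands at a limit and not at a number: (the limit of < 100 mg/kg in this assay, at which 1 of the 4 values shown sits). Among the compounds shown here, the earlier compounds carried an aromatic group at this position only with a further substituent on the phenyl and with a different chain at the far end of the core, so this pair is the first to isolate the change, though it gives a direction without a size, and compound 4 cannot be set in order against compound 2 or compound 3.

From the compounds shown here alone, how large the step is stays open, as compound 1 and compound 4 both end at limits in this assay and neither has a number. Also open, going by these compounds, is how an amine, a carboxylic acid or a benzyl group on this same aromatic carbon would read in this assay on the core of compound 1.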